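This account rests on a few compounds, and the source may have more. Where it says the series, first, only, none or still open, it means among the compounds named here.

Notes on the series in a functional assay on NCI-H292 cells (Homo sapiens) for antiproliferative activity; on this read-out lower numbers stand for stronger inhibition and higher numbers for weaker inhibition. Compound 1 `Cc1cccc(N2C(=O)N/C(=C\c3ccc(O)cc3)C2=O)c1` gives in this assay only a limit of the assay, > 200000 nM. Compound 2 `O=C1N/C(=C\c2ccc(O)cc2)C(=O)N1c1cccc(Br)c1` likewise gives only a limit, > 200000 nM. The step that the two limits leave unreadable from compound 1 to compound 2 therefore cannot be read, since both values sit at the limit (the limit of > 200000 nM in this assay, at which 2 of the 2 values shown sit). On the numbers shown, compound 2 stands at a limit and nowhere else; no measured step in the series has a readable size. Compound 3 `O=C(NCc1ccccc1)c1cccc(N2C(=O)N/C(=C\c3ccc(O)cc3)C2=O)c1` differs from compound 2 by benzylcarbamoyl in place of bromo on an aromatic carbon. Among the measured compounds shown here, the only measured step that bears on this change is a step that the two limits leave unreadable from compound 1 to compound 2, and it gives no size and no direction at all. The expected step of a number no higher from compound 2 to compound 3 (the limit leaves the size open) is accordingly one of no readable change, with the number most likely again reported only as a limit. Compound 3 is estimated at 200000 nM, within 50000 nM to 600000 nM.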

Compound 3, half-maximal inhibitory concentration: 23500 nM
Compound 3: the middle estimate sits 8.5-fold (0.93 log units) above what was measured; the measured number lies below the stated range.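

In this assay, benzylcarbamoyl in place of bromo gives an at least 8.5-fold lower number from compound 2 to compound 3 (0.92 log units; beyond the scatter), and benzylcarbamoyl in place of methyl gives an at least 8.5-fold lower number from compound 1 to compound 3 (0.92 log units; beyond the scatter). This aromatic carbon, meta to a large group, can therefore carry a change that moves the read-out, which the methyl and bromo pair could not show. Both steps are bounds and their full size stays open: the limit of > 200000 nM in this assay, at which 2 of the 3 values shown sit.

The compounds shown leave open whether the change in number goes with the amide carbonyl and its hydrogen or with the added phenyl ring; a primary carboxamide, a carboxylic acid or a phenethylcarbamoyl group at this place would separate these. As far as these compounds go, it also remains open whether benzylcarbamoyl would give a similar step on another carbon of the same ring.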